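This account rests on a few compounds, and the source may have more. Where it says the series, first, only, none or still open, it means among the compounds named here.

Measured compounds:
compound 1 `COc1ccc(C(=O)/C=C/c2ccc(N(C)C)cc2)c2c1C=CC(C)(C)O2`, 3500 nM
compound 2 `CCN(CC)c1ccc(/C=C/C(=O)c2ccc(OC)c3c2OC(C)(C)C=C3)cc1`, 790 nM
compound 3 `COc1ccc(C(=O)/C=C/c2ccc(OC)c(OC)c2OC)c2c1C=CC(C)(C)O2`, a limit of the assay

In a functional assay on K562 cells (Homo sapiens) for antiproliferative activity, read by MTT assay, with a stated time of 24 h (on this read-out lower numbers stand for stronger inhibition and higher numbers for weaker inhibition), compound 1 gives 3500 nM, the highest of the two numbers shown. Its nearest neighbour is compound 2, which gives 790 nM; the change is a 4.4-fold lower number from compound 1 to compound 2 (0.65 log units; beyond the scatter). Compound 3 gives > 10000 nM, a limit of the assay and not a number, namely (the limit of > 10000 nM in this assay, at which 1 of the 3 values shown sits).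

Compound 4 `COc1ccc(C(=O)/C=C/c2cccs2)c2c1C=CC(C)(C)O2` is not yet measured. It differs from compound 1 in one place: thiophen-2-yl in place of 4-(dimethylamino)phenyl on a double-bonded chain carbon bound to a double-bonded chain carbon.

Going by the values given here, no measured step covers this change directly. The step from compound 1 to compound 2 varies only the amino group on the aryl ring and says nothing about removing that ring. Compound 3, with a methoxylated aryl ring in the same place, sits at the limit, which suggests that this position tolerates change poorly, although one such value is weak evidence. Compound 4 is therefore expected to give a somewhat higher number than compound 1, an estimated 1.7-fold higher number from compound 1 to compound 4 (0.23 log units; within the scatter), with a real chance that it too ends at a limit. Compound 4 is estimated at 6000 nM, in a range from 2000 nM to 20000 nM.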

Compound 4, half-maximal inhibitory concentration: > 10000 nM
Compound 4: no number, only a limit; the forecaster's own chance of this, stated with the estimate: 35%; middle value at least 1.6-fold (0.22 log units) away from the limit.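

In this assay, replacing the whole aryl group rather than only its amino substituent gives an at least 2.8-fold higher number from compound 1 to compound 4 (0.45 log units; beyond the scatter), the first step shown in which a change at this place moves the read-out upward beyond the scatter. Compound 4 gives > 10000 nM, which is a limit of the assay and not a number, so the step sets only a lower bound on the size of the change. Among the four compounds shown, the two with a dimethylamino or diethylamino group on the phenyl ring, compound 1 and compound 2, give numbers, whereas compound 3 and compound 4, which have no amino group, both end at the limit, and no compound shown goes against this pattern: the limit of > 10000 nM in this assay, at which 2 of the 4 values shown sit.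

Going by these compounds, how far compound 4 lies beyond the limit stays unknown, and compound 3 and compound 4 cannot be ranked against each other. The compounds shown also do not separate the loss of the amino group from the exchange of the phenyl ring for thiophen-2-yl, a question that an unsubstituted phenyl or a thiophen-2-yl bearing a dimethylamino group would address.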